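Adding a hydroxy group to a dienone from a pair of diketones

This account rests on a few compounds, and the source may have more. Where it says the series, first, only, none or still open, it means among the compounds named here.

The compounds here were tested in an ADME assay on PC-12 cells (Rattus norvegicus) for cytotoxicity, read by WST assay, with a stated time of 24 h; on this read-out higher numbers stand for lower toxicity in this test and lower numbers for higher toxicity in this test. Compound 1, `O=C(/C=C/c1ccc(O)c(O)c1)CC(=O)/C=C/c1cc(O)ccc1O`, gives 51000 nM in this assay. Compound 2, `O=C(/C=C/c1cccc(O)c1)CC(=O)/C=C/c1cc(O)ccc1O`, gives 15000 nM in this assay. Compound 1 differs from compound 2 by hydroxy in place of hydrogen on an aromatic carbon, and this change brings a 3.4-fold higher number from compound 2 to compound 1 (0.53 log units; beyond the scatter). Compound 3, `O=C(/C=C/c1cccc(O)c1)/C=C/c1ccc(O)c(O)c1`, has a shorter linker between its two rings; the difference between its core and the core of compound 2 is not broken down here. In this assay compound 3 reaches only a limit, > 100000 nM, and gives no number; this limit, (the limit of > 100000 nM in this assay, at which 1 of the 3 values shown sits), marks the edge of what this test can report.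

Compound 4, `O=C(/C=C/c1ccc(O)c(O)c1)/C=C/c1cc(O)ccc1O`, is still to be measured. It differs from compound 3 by hydroxy in place of hydrogen on an aromatic carbon. Among the compounds with values here, this is the same kind of change as the one from compound 2 to compound 1, but not the same: in compound 1 the entering hydroxy sits ortho to a hydroxy group and para to a large group, while in compound 4 it sits ortho to a large group and para to a hydroxy group. Since the change from compound 2 to compound 1 gave a 3.4-fold higher number from compound 2 to compound 1 (0.53 log units; beyond the scatter), and since compound 3 already sits at the limit with > 100000 nM, compound 4 is expected to sit at or beyond the same limit, with an expected step that the limit leaves unreadable from compound 3 to compound 4. The estimate for compound 4 in this assay is 150000 nM, with an expected range from 60000 nM to 400000 nM.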

Compound 4, half-maximal cytotoxic concentration: 39000 nM
Compound 4: the middle estimate sits 3.8-fold (0.59 log units) above what was measured; the whole stated range lies above it.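

Compound 3 gives > 100000 nM in this assay, and this is a limit of the test, not a number. Placing a hydroxy on an aromatic carbon of compound 3, ortho to a large group and para to a hydroxy group, brings an at least 2.5-fold lower number from compound 3 to compound 4 (0.40 log units; beyond the scatter), so the number moves the opposite way from the earlier step on the other core: the same change on two cores in this assay, a 3.4-fold higher number (0.53 log units; beyond the scatter) from compound 2 to compound 1 and an at least 2.5-fold lower number (0.40 log units; beyond the scatter) from compound 3 to compound 4, at least 8.7-fold (0.94 log units) apart, beyond the scatter of two such steps. This shows that the direction of the step did not carry from one core to the other in these two pairs, but it does not show whether the core itself or the different place of the entering hydroxy sets the direction, since the two pairs differ in both, and two pairs cannot establish a rule for the series.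

The compounds shown leave open whether hydroxy at the same place on each core would give the same split, and whether a methoxy group or an amine in that place would follow the hydroxy steps. They also leave open how a longer chain between the two rings would change the picture, and how large the step from compound 3 really is.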